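The source may hold more compounds than are shown below. What is called first, only, known or untested is meant among the compounds shown, and "the series" means these compounds.

Within the data shown here, in a functional assay (Homo sapiens) for antiproliferative activity, read by resazurin assay, with a stated time of 48 h, tested at 10 uM (a lower number here means a weaker effect, a higher number a stronger effect of the compound at the concentration tested), compound 2 `COc1cc(OC)c2c(=O)cc(-c3ccc(OCCCN(C)C)cc3)oc2c1` gives 59%, the only number in hand; compound 1 `COc1cc(OC)c2c(=O)cc(-c3ccc(OCCBr)cc3)oc2c1` is recorded as "not active" (no number reported) with no figure attached. Compound 3 `COc1cc(OC)c2c(=O)cc(-c3ccc(OCCN4CCCC4=O)cc3)oc2c1` has not been measured. It differs from compound 2 by 2-oxopyrrolidin-1-yl in place of (dimethylamino)methyl on a saturated chain carbon, two bonds along the chain from an oxygen on an aromatic ring. Among the measured compounds shown here, no step between two measured compounds is available to tell the size of such a change, so any expectation rests on compound 2 alone. Compound 3 is expected to give about 30%, within 5% to 55%. This estimate means a step of a number 29 percentage points lower from compound 2 to compound 3 (beyond the scatter), expected to fall beyond the scatter toward a weaker effect.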

Compound 3, a percentage reported as inhibition, at one concentration (the size of the read-out at that concentration, not a potency): 14%
The estimate for compound 3 lay 16 percentage points above the measured number, and the stated range covers the measured number.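

In this assay, among these compounds, putting 2-(2-oxopyrrolidin-1-yl)ethoxy in place of 3-(dimethylamino)propoxy brings a number 45 percentage points lower from compound 2 to compound 3 (beyond the scatter), the first sized change at this position, and it shows that the read-out depends strongly on the group carried there. Compound 3 still gives a figure, whereas compound 1 is recorded as "not active" (no number reported). Nothing available bears on the reason for this drop. Open, on these data alone, is whether 2-(dimethylamino)ethoxy or 2-(pyrrolidin-1-yl)ethoxy, amines without the carbonyl, would stay near compound 2 or fall toward compound 3.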